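Swapping Hydroxy for Hydroxyamino on a Bromo-Indazole

The source may report more compounds than this note shows. Statements on the series, on what has been measured and on what is new or still open speak of the compounds shown alone.

Measured so far:
- Compound 1, `Oc1cccc(CNc2cc(Br)cc3[nH]ncc23)c1`: 55%
- Compound 2, `CC(=O)Nc1ccc(CNc2cc(Br)cc3[nH]ncc23)cc1`: "not active" (no number reported)
- Compound 3, `ONc1ccc(CNc2cc(Br)cc3[nH]ncc23)cc1`: 6%

In an assay for inhibition of Tryptophan 2,3-dioxygenase (Homo sapiens), with a stated time of 1 h, tested at 10 uM (on this read-out higher numbers stand for more inhibition at the one concentration tested (going by the name of the read-out) and lower numbers for less inhibition), compound 1 gives the highest of the two reported numbers, standing well beyond the scatter above compound 3, which gives 6%; compound 2 has no number at all and is reported as not active. Compound 4, `ONc1cccc(CNc2cc(Br)cc3[nH]ncc23)c1`, is not yet measured. It differs from compound 1 in one spot: hydroxyamino in place of hydroxy on an aromatic carbon. Compound 3 already carries a hydroxyamino group and scores low, so a step downward that goes beyond the scatter is expected here, though a group in a different place need not behave the same way. The estimate for compound 4 is 25%, in a range from 5% to 50%, a step of a number 30 percentage points lower from compound 1 to compound 4 (beyond the scatter) expected from the change.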

Compound 4, a percentage reported as inhibition, at one concentration (the size of the read-out at that concentration, not a potency): "not active" (no number reported)
Compound 4: no number reported, so the estimate cannot be set against anything.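

Within the data shown here, compound 4 is reported as not active, with no number, so no step from compound 1 can be read. Nothing shown here offers an explanation. The compounds shown leave open how large the effect of hydroxyamino in place of hydroxy is.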